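A few compounds are considered here, and "the series" means these few. Any claim that something is new, unique, unknown or untested is made for them only; others in the source may bear on it.

Measured so far, in a functional assay on HCC 2998 cells (Homo sapiens) for antiproliferative activity, with a stated time of 48 h; a higher number here means a weaker inhibitor of growth, a lower number a stronger inhibitor of growth:
compound 1 `Cc1cc(O)c(C2=NN(c3ccc(S(N)(=O)=O)cc3)C(c3ccccc3O)C2)cc1Cl` gives 4310 nM;
compound 2 `Cc1cc(O)c(C2=NN(c3ccc(S(N)(=O)=O)cc3)C(/C=C/c3ccccc3)C2)cc1Cl` gives 30300 nM.

Among the measured compounds shown here, compound 2 stands at the highest number of the two; the only step, a 7.0-fold higher number from compound 1 to compound 2 (0.85 log units; beyond the scatter), is beyond the scatter. Compound 3 `COc1ccc(C2CC(c3cc(Cl)c(C)cc3O)=NN2c2ccc(S(N)(=O)=O)cc2)cc1OC` differs from compound 2 by 3,4-dimethoxyphenyl in place of 2-phenylethenyl on a saturated ring carbon. That change again places an aromatic ring directly on the saturated ring carbon, as in compound 1. The step from compound 1 to compound 2 bears on it and ran against the aryl-to-alkenyl change; compound 3 is therefore expected to run back, with an estimated 5.1-fold lower number from compound 2 to compound 3 (0.70 log units; beyond the scatter). For compound 3 the expected value in this assay is 6000 nM, within 2000 nM to 20000 nM.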

Compound 3, concentration for total growth inhibition: 7250 nM
For compound 3 the middle estimate is 1.2-fold (0.08 log units) below the measured one, within the range that was stated.
By their numbers in this assay, from the lowest: compounds 1 and 3 (each within the scatter of the next); then compound 2.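

In this assay, a second aromatic ring on the saturated ring carbon again stands apart from 2-phenylethenyl (a 4.2-fold lower number from compound 2 to compound 3 (0.62 log units; beyond the scatter)), so the gap seen with compound 1 is not tied to the 2-hydroxyphenyl group alone. The two aryl groups are not told apart at this position (a 1.7-fold higher number from compound 1 to compound 3 (0.23 log units; within the scatter)), and the added methoxy groups of compound 3 show no separate effect. No evidence on the cause of these steps is at hand. Still open, as far as these compounds go, is whether a saturated alkyl chain or an amine at this carbon would track with 2-phenylethenyl or with the aryl groups.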